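Weak antiproliferative activity across a small amide series

The source may report more compounds than this note shows. Statements on the series, on what has been measured and on what is new or still open speak of the compounds shown alone.

Measured compounds:
compound 1 `CCNC(=O)c1cc(Oc2ccc(NC(=O)c3nn(-c4ccccc4C)c(=O)cc3C)cc2)ccn1` — 44300 nM
compound 2 `CNC(=O)c1cc(Oc2ccc(NC(=O)c3nn(-c4ccccc4Cl)c(=O)cc3C)cc2F)ccn1` — 136000 nM
compound 3 `CCCNC(=O)c1cc(Oc2ccc(NC(=O)c3nn(-c4ccc(Br)cc4F)c(=O)cc3C)cc2F)ccn1` — "not active" (no number reported)

The three measured compounds share a core and differ in the amide chain and in the aryl group on the aromatic nitrogen. In a functional assay on MCF7 cells (Homo sapiens) for antiproliferative activity, read by MTT assay, with a stated time of 72 h (a lower number here means a stronger inhibitor, a higher number a weaker inhibitor), compound 1 gives 44300 nM, and compound 2 gives 136000 nM. Within the data shown here, compound 3, carrying a propyl amide and a 4-bromo-2-fluorophenyl group, is reported in this assay as "not active" (no number reported), so no number stands for it, and no single step between two measured compounds can be computed from these data.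

Compound 4 `CCCNC(=O)c1cc(Oc2ccc(NC(=O)c3nn(-c4cccc(F)c4)c(=O)cc3C)cc2F)ccn1` differs from compound 3 in one place: 3-fluorophenyl in place of 4-bromo-2-fluorophenyl on an aromatic nitrogen. Among the measured compounds shown here, with no number for compound 3 and no computed step, the size of this change cannot be read from a neighbour pair; since all three measured compounds are weak or without activity in this assay, compound 4 is expected to remain weak, with a real chance that only a limit is reported. Compound 4 is estimated to give about 100000 nM in this assay, within a range of 30000 nM to 400000 nM.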

Compound 4, half-maximal inhibitory concentration: 13300 nM
Estimate against measurement, compound 4: 7.5-fold (0.88 log units) above, outside the stated range (below it).
By their numbers in this assay, from the lowest: compound 4; then compound 1; then compound 2.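

No new step can be read: compound 3 is reported as "not active" without a number, so its pair with compound 4 gives no size of change. The compounds shown leave open how much this aryl swap alone matters, and no evidence here bears on the result.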